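The source may report more compounds than this note shows. Statements on the series, on what has been measured and on what is new or still open speak of the compounds shown alone.

Working notes on the series. Three compounds sharing one core have numbers in an ADME assay on Vero cells (Chlorocebus sabaeus) for cytotoxicity; a lower number here means that less compound is tolerated, a higher number that more compound is tolerated. Compound 1 `COc1ccc(-c2nc3c(C(=O)NCCCO)cccc3[nH]2)c(OC)c1OC` gives 40 uM, compound 2 `CCC(CC)NC(=O)c1cccc2[nH]c(-c3ccc(OC)c(OC)c3OC)nc12` gives 32.3 uM and compound 3 `COc1ccc(-c2nc3c(C(=O)Nc4cnc(Cl)cn4)cccc3[nH]2)c(OC)c1OC` gives 65.2 uM. Compound 3 stands highest of the three, though its distance to compound 1 is small: a 1.6-fold higher number from compound 1 to compound 3 (0.21 log units; within the scatter). The gap to compound 2 is larger: a 2.0-fold higher number from compound 2 to compound 3 (0.31 log units; beyond the scatter). Between the two chain-bearing amides the numbers are indistinguishable: a 1.2-fold lower number from compound 1 to compound 2 (0.09 log units; within the scatter).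

The next compound, compound 4 `COc1ccc(-c2nc3c(C(=O)Nc4nc5ccccc5[nH]4)cccc3[nH]2)c(OC)c1OC`, carries the change (1H-benzimidazol-2-yl in place of 5-chloropyrazin-2-yl on an amide-type nitrogen). The steps measured so far all exchange one substituent on the amide-type nitrogen, and the two that end at compound 3 swap a chain for one six-membered aromatic ring with 2 hetero atoms. For the measured compounds named here, the present step swaps that ring for a fused two-ring group and has no direct counterpart among the measured pairs. Going by the values given here, since every change at this position so far moved the number by at most a modest amount, no step beyond the scatter is expected in this assay for compound 4, with the estimated step being a 1.2-fold lower number from compound 3 to compound 4 (0.07 log units; within the scatter). Compound 4 is therefore expected to give about 55 uM, within a range from 25 uM to 110 uM.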

Compound 4, half-maximal toxic concentration: 29 uM
Compound 4: middle estimate off by 1.9-fold (0.28 log units), on the high side, within the range that was stated.
By their numbers in this assay, from the lowest: compounds 4, 2, 1 and 3 (each within the scatter of the next, the first and the last beyond it).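

In this assay, the exchange of 5-chloropyrazin-2-yl for 1H-benzimidazol-2-yl on the amide-type nitrogen gives a 2.2-fold lower number from compound 3 to compound 4 (0.35 log units; beyond the scatter) and shows that an aromatic ring system at this position does not by itself go with the number of compound 3. Compound 4 instead stays level with the amides bearing open chains, with a 1.1-fold lower number from compound 2 to compound 4 (0.05 log units; within the scatter) and a 1.4-fold lower number from compound 1 to compound 4 (0.14 log units; within the scatter), so that compound 3 stands beyond the scatter from compound 2 and compound 4, while compound 1 lies within the scatter of all three. Nothing available on these compounds accounts for the difference between the two ring groups.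

The step replaces the chlorine, adds a fused carbon-only six-membered ring and brings in a hydrogen-bond donor all at once, and the compounds shown do not separate these parts. As far as these compounds go, it stays open whether a pyrazin-2-yl group without the chlorine, a plain phenyl or a 1H-indol-2-yl group on the amide-type nitrogen would stand with compound 3 or with compound 4.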